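The source may report more compounds than this note shows. Statements on the series, on what has been measured and on what is new or still open speak of the compounds shown alone.

Measured so far in a functional assay on A549 cells (Homo sapiens) for antiproliferative activity, read by MTT assay, with a stated time of 24 h; a lower number here means a stronger inhibitor, a higher number a weaker inhibitor:
compound 1 `COc1cc(C(=O)/C=C/c2cc(-c3cc(OC)c(OC)c(OC)c3)n3nc(-c4ccccc4)cc3n2)cc(OC)c1OC` gives 20500 nM
compound 2 `COc1ccc(-c2cc(/C=C/C(=O)c3cc(OC)c(OC)c(OC)c3)nc3cc(-c4ccccc4)nn23)cc1OC` gives 7200 nM
compound 3 `COc1ccc(-c2cc(C(=O)/C=C/c3ccc(C)cc3)nc3cc(-c4ccccc4)nn23)cc1OC` gives 22200 nM

Compound 1 stands second highest of the three numbers in this assay. Its nearest neighbour is compound 3, whose value lies within the scatter of that of compound 1. Going by the values given here, the only step recorded within one change is a 2.8-fold lower number from compound 1 to compound 2 (0.45 log units; beyond the scatter), a modest step and the single step beyond the scatter in the set; it concerns a methoxy group on the aryl ring of the core and not the enone.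

Compound 4 `COc1cc(-c2cc(/C=C/C(=O)c3ccc(C)cc3)nc3cc(-c4ccccc4)nn23)cc(OC)c1OC` differs from compound 1 by 4-methylphenyl in place of 3,4,5-trimethoxyphenyl on a carbonyl carbon. Among the compounds with values here, no measured step touches this position. Compound 3 carries a 4-methylphenyl group as well, though on the chain carbon rather than on the carbonyl, and in this assay compound 3 gives 22200 nM, which sits within the scatter of compound 1. Within the data shown here, that is the only bearing the measured numbers have on the change, and it is an indirect one. The expectation is therefore no step beyond the scatter, and the estimated step of a 1.0-fold lower number from compound 1 to compound 4 (0.01 log units; within the scatter) reflects this. For compound 4 the estimated value in this assay is 20000 nM, expected to fall between 7000 nM and 60000 nM.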

Compound 4, half-maximal inhibitory concentration: 19400 nM
The estimate for compound 4 lay 1.0-fold (0.01 log units) above the measured number; measured number inside the range.
By their numbers in this assay, from the lowest: compound 2; then compounds 4, 1 and 3 (each within the scatter of the next).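

Going by these compounds alone, at the carbonyl carbon, 4-methylphenyl in place of 3,4,5-trimethoxyphenyl in this assay gives a 1.1-fold lower number from compound 1 to compound 4 (0.02 log units; within the scatter) and provides the first direct reading at this position. The entering group has 7 heavy atoms and 0 hydrogen-bond acceptors, fewer of both than the group that leaves, so in this pair neither the three methoxy groups nor the larger aryl group is needed to keep the number where compound 1 stands, whereas the methoxy change on the aryl ring of the core gives a 2.8-fold lower number from compound 1 to compound 2 (0.45 log units; beyond the scatter) and lies beyond the scatter. No supporting measurement offers an explanation for this result.

Within the data shown here, the pair does not show whether the same change would stay within the scatter when made on compound 2, the only compound here whose number is separated from that of compound 1 by a step beyond the scatter. It also leaves open how a carboxylic acid or a dimethylamino group in place of the 4-methylphenyl on the carbonyl carbon would read in this assay, since both aryl groups seen at this position carry only methyl or methoxy groups.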